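A few compounds are considered here, and "the series" means these few. Any claim that something is new, unique, unknown or untested is made for them only; others in the source may bear on it.

- Compound 1 `COc1cc(O)c(C(=O)/C=C/c2cccc(O)c2)c(OC)c1`: 9900 nM
- Compound 2 `CCc1ccccc1/C=C/C(=O)c1c(O)cc(OC)cc1OC`: 2500 nM

In a functional assay on B16-F10 cells (Mus musculus) for inhibition, with a stated time of 4 days (on this read-out higher numbers stand for weaker inhibition and lower numbers for stronger inhibition), compound 2 gives the lower of the two numbers, 2500 nM, while compound 1 gives 9900 nM. That gap lies beyond the usual scatter, but these two compounds differ in more than one place, so it reveals nothing about any single change.

Compound 3 `COc1cc(O)c(C(=O)/C=C/c2ccccc2C)c(OC)c1` is closely related to compound 2. The change is hydrogen in place of methyl on a saturated chain carbon bound to an aromatic carbon, so ethyl becomes methyl. Going by the values given here, no measured pair shows this change. The best starting point is therefore compound 2 at 2500 nM, and in this assay I expect no step beyond the scatter, with at most a slight drift towards a higher number. The expected change is a 1.2-fold higher number from compound 2 to compound 3 (0.08 log units; within the scatter). For compound 3 the estimated value is 3000 nM, with an expected range of 1200 nM to 7500 nM.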

Compound 3, half-maximal inhibitory concentration: 3000 nM
Beside the measured number, compound 3's estimate shows no gap at the digits printed; the measured number falls inside the stated range.
By their numbers in this assay, from the lowest: compounds 2 and 3 (each within the scatter of the next); then compound 1.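

In this assay the change from ethyl to methyl gives a 1.2-fold higher number from compound 2 to compound 3 (0.08 log units; within the scatter) and so, on this shared core, removing one methyl from the saturated chain carbon bound to an aromatic carbon leaves no difference that can be told from the scatter. Going by these compounds alone, compound 3 also allows the first comparison of compounds that differ in one place at the other end of the scale: 2-methylphenyl in place of 3-hydroxyphenyl gives a 3.3-fold lower number from compound 1 to compound 3 (0.52 log units; beyond the scatter) and this modest step lies beyond the scatter. Nothing available here explains either step.

Still open, going by these compounds, is whether a longer chain such as propyl would also sit within the scatter of ethyl and methyl. An amine or a carboxylic acid on that same chain carbon remains an untested kind of group among the compounds shown.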